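The source may report more compounds than this note shows. Statements on the series, on what has been measured and on what is new or still open speak of the compounds shown alone.

Compound 2 `COc1cc(Nc2nc3ccccc3nc2S(=O)(=O)c2ccc(Br)cc2)cc(OC)c1` is the weaker of the two measured compounds in a functional assay on HCT-116 cells (Homo sapiens) for cytotoxicity, read by MTT assay, with a stated time of 72 h; on this read-out higher numbers stand for weaker inhibition and lower numbers for stronger inhibition. In this assay compound 2 gives only a limit of the assay, > 50000 nM, and no number. Compound 1 `COc1ccc(S(=O)(=O)c2nc3ccccc3nc2Nc2cc(OC)cc(OC)c2)cc1` differs from it by a methoxy in place of the bromo on the aromatic carbon, and in this assay compound 1 gives 13400 nM. Within the data shown here, the only measured step, an at least 3.7-fold higher number from compound 1 to compound 2 (0.57 log units; beyond the scatter), runs up to the limit of > 50000 nM in this assay, at which 1 of the 2 values shown sits, so its true size is open at the top. Compound 3 `COc1cc(Nc2nc3ccccc3nc2S(=O)(=O)c2ccc(F)cc2)cc(OC)c1` carries fluoro in place of bromo on an aromatic carbon. Among the measured compounds shown here, no measured pair exchanges one halogen for another, so there is no step that bears directly on this change; the one measured step shows only that the halogen-bearing compound 2 sits at the limit. Compound 3 is therefore expected to stay weak, with a step of an at least 1.1-fold lower number from compound 2 to compound 3 (0.04 log units; that floor lies within the scatter) that is not expected to pass beyond the scatter. The estimate for compound 3 in this assay is 45000 nM, within a range from 12000 nM to 150000 nM.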

Compound 3, half-maximal inhibitory concentration: 3930 nM
The estimate for compound 3 lay 11-fold (1.06 log units) above the measured number, and the stated range ends above it.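

In this assay, among these compounds, fluoro in place of bromo on this aromatic carbon gives an at least 12-fold lower number from compound 2 to compound 3 (1.10 log units; beyond the scatter), which shows that the choice of halogen at this position counts for a great deal, something no earlier pair could show. Fluoro also differs from methoxy here, with a 3.4-fold lower number from compound 1 to compound 3 (0.53 log units; beyond the scatter), so the three groups now fall into an order, with fluoro giving the lowest number, methoxy the next and bromo the highest. The value of compound 2 is only a limit, so the first of these steps remains open at the top: the limit of > 50000 nM in this assay, at which 1 of the 3 values shown sits.

The compounds shown leave open where chloro, a nitrile or an amine on this carbon would fall relative to fluoro. They also leave open whether the order of the three groups would hold with a different aniline on the shared core.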